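Pyrazine Hydrazones: Predicting a Methoxy Analogue's Cytotoxicity

The source may hold more compounds than are shown below. What is called first, only, known or untested is meant among the compounds shown, and "the series" means these compounds.

Measured compounds:
compound 1 `O=C(N/N=C/c1ccc(Cl)cc1)c1cnccn1`, 56%
compound 2 `O=C(N/N=C/c1ccc(F)cc1)c1cnccn1`, 71%
compound 3 `O=C(N/N=C/c1ccccc1Br)c1cnccn1`, 91%

Three hydrazones sharing one pyrazine carbonyl core have been tested in an ADME assay on J774 cells (Mus musculus) for cytotoxicity, read by MTT assay, with a stated time of 48 h, tested at 150 ug/mL; on this read-out lower numbers stand for a stronger effect and higher numbers for a weaker effect at the one concentration tested. Compound 2 stands second highest of the three numbers, beyond the scatter from both of the others: its nearest neighbour is compound 1, which gives a lower number, and the furthest is compound 3, which gives a higher number.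

The unmeasured compound 4 `COc1ccc(/C=N/NC(=O)c2cnccn2)cc1` differs from compound 2 in one place: methoxy in place of fluoro on an aromatic carbon. Among the measured compounds shown here, the only step recorded among the measured compounds is a number 15 percentage points higher from compound 1 to compound 2 (beyond the scatter), a modest shift for the exchange of one halogen against another. For the measured compounds named here, no measured step exchanges a halogen for a methoxy group, so that step bears on the present change only as a gauge of how much a single substituent swap on this ring has moved the read-out.

Going by the values given here, with no direct precedent, the expectation for compound 4 in this assay is a step of a number 4 percentage points higher from compound 2 to compound 4 (within the scatter), that is no change beyond the scatter. Compound 4 is therefore estimated at 75%, with a range from 58% to 92%.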

Compound 4, a percentage reported as activity, at one concentration (the size of the read-out at that concentration, not a potency): 55%
Compound 4: the middle estimate sits 20 percentage points above what was measured; the whole stated range lies above it.
By their numbers in this assay, from the lowest: compounds 4 and 1 (each within the scatter of the next); then compound 2; then compound 3.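

In this assay, fluoro and methoxy on this aromatic carbon, para to a large group, are not interchangeable: the exchange gives a number 16 percentage points lower from compound 2 to compound 4 (beyond the scatter). Methoxy in place of chloro at the same carbon gives a number 1 percentage points lower from compound 1 to compound 4 (within the scatter), so among these three groups fluoro alone stands apart, something the single step between the two halogens could not show. The read-out at this carbon therefore does not simply divide halogens from a group without a halogen, since the two halogens differ beyond the scatter while chloro and methoxy do not.

No measurement of any property accompanies these numbers, so nothing shown accounts for the differences between these groups.

The compounds shown leave open how an amine or a hydroxyl group on this carbon would read, and whether a longer chain such as ethoxy would stay with methoxy and chloro or move towards fluoro. They also leave open whether the exchange of fluoro for methoxy would give a step of this size on a different core.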